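Swapping a Furan Ring for a Thiophene Ring

The source may report more compounds than this note shows. Statements on the series, on what has been measured and on what is new or still open speak of the compounds shown alone.

In a functional assay on K562 cells (Homo sapiens), read by MTT assay, with a stated time of 72 h (a lower number here means a stronger inhibitor, a higher number a weaker inhibitor), three compounds have results so far. Compound 1 `CSc1ncnc2c1c(-c1ccsc1)cn2[C@@H]1O[C@H](CO)[C@@H](O)[C@H]1O` gives only a limit of > 20000 nM and no exact number. Compound 2 `C#Cc1cn([C@@H]2O[C@H](CO)[C@@H](O)[C@H]2O)c2ncnc(NC)c12` reads 1380 nM as an exact number. Compound 3 `Nc1nc2c(c(-c3ccoc3)cn2[C@@H]2O[C@H](CO)[C@@H](O)[C@H]2O)c(=O)[nH]1` reads 12500 nM and this is the higher of the two exact numbers, so it is the weaker of that pair, by a gap beyond the usual scatter.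

Compound 4 `Nc1nc2c(c(-c3ccsc3)cn2[C@@H]2O[C@H](CO)[C@@H](O)[C@H]2O)c(=O)[nH]1` has not been measured yet. It carries thiophen-3-yl in place of furan-3-yl on an aromatic carbon and is otherwise the same as compound 3. Going by the values given here, no measured pair here differs in only one place, so the forecast has no direct precedent. Starting from compound 3 at 12500 nM and with one five-membered aromatic ring replacing another, the expectation in this assay is no step beyond the scatter in either direction. The expected step of a 1.0-fold lower number from compound 3 to compound 4 (0.02 log units; within the scatter) is accordingly small. Compound 4 is estimated at 12000 nM (expected range 4500 nM to 20000 nM).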

Compound 4, half-maximal inhibitory concentration: 18300 nM
For compound 4 the middle estimate is 1.5-fold (0.18 log units) below the measured one, within the range that was stated.
By their numbers in this assay, from the lowest: compound 2; then compounds 3 and 4 (each within the scatter of the next). At a limit, above all of these: compound 1.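

In this assay, putting thiophen-3-yl in place of furan-3-yl gives a 1.5-fold higher number from compound 3 to compound 4 (0.17 log units; within the scatter), so this assay does not separate the two rings at this position. Going by these compounds alone, this is the first pair here that differs in only one place, and it shows that exchanging the oxygen of this five-membered aromatic ring for sulfur, on an otherwise unchanged compound, leaves the reading within the scatter. Compound 1 gives only a limit, and that limit marks the top of the readings in this series: the limit of > 20000 nM in this assay, at which 1 of the 4 values shown sits.

From the compounds shown here alone, what a different kind of group would do at this aromatic carbon stays open, whether a phenyl ring, an amine or a longer alkyl chain. A single pair also does not tell whether the same ring exchange would behave alike on a different core.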